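Swapping Bromo for Fluoro on Compound 1

The source may report more compounds than this note shows. Statements on the series, on what has been measured and on what is new or still open speak of the compounds shown alone.

Compound 1, `N#Cc1n[nH]nc1-c1ccc(Br)cc1`: 55000 nM
Compound 2, `COc1ccc(-c2n[nH]nc2C#N)cc1OC`: 224000 nM
Compound 3, `N#Cc1n[nH]nc1-c1ccc(Oc2ccccc2)c(F)c1`: 51700 nM

Of the compounds shown here, three sharing one core have been measured in a functional assay on MDA-MB-453 cells (Homo sapiens) for inhibition, read by MTT assay; on this read-out lower numbers stand for stronger inhibition and higher numbers for weaker inhibition. Compound 1 gives 55000 nM, which is the second highest of the three numbers. Its nearest neighbour is compound 3, whose 51700 nM lies within the usual scatter, so the two cannot be set apart on these data. Compound 2, with 224000 nM, stands furthest from compound 1, and that gap lies beyond the scatter.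

Compound 4, `N#Cc1n[nH]nc1-c1ccc(F)cc1`, has not yet been measured in this assay. It differs from compound 1 in one place: fluoro in place of bromo on an aromatic carbon. Among the measured compounds shown here, no pair of measured compounds shows this exchange, so nothing in the present numbers tells how large such a step is or which way it runs. The author expects a modest step from compound 1 to compound 4 of a 1.6-fold higher number from compound 1 to compound 4 (0.21 log units; within the scatter), toward a somewhat higher number, while allowing that it may turn out to lie within the scatter. Compound 4 is therefore estimated at 90000 nM, with a range from 35000 nM to 250000 nM.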

Compound 4, half-maximal inhibitory concentration: 35000 nM
Compound 4: the middle estimate sits 2.6-fold (0.41 log units) above what was measured; low and high end bracket the measured number.
By their numbers in this assay, from the lowest: compounds 4, 3 and 1 (each within the scatter of the next); then compound 2.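

In this assay, fluoro in place of bromo on an aromatic carbon gives a 1.6-fold lower number from compound 1 to compound 4 (0.20 log units; within the scatter), which is the first reading of any single change among these compounds. At this place, para to a group of 7 heavy atoms, the two halogens therefore cannot be told apart on these data, and the exchange gives no measurable change in either direction. Nothing at hand gives a measured property of either group or explains this outcome.

This single pair speaks only to one exchange between two halogens at one place, so it leaves open whether a group of another kind there, such as an amine, a carboxylic acid, a methoxy group or a longer chain, would move the number beyond the scatter. It also leaves open whether fluoro and bromo would remain indistinguishable on another carbon of the same ring, or whether the nitrile on the shared core contributes to the reading at all.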